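The source may report more compounds than this note shows. Statements on the series, on what has been measured and on what is new or still open speak of the compounds shown alone.

Compound 1 `CCc1ccc2c(c1)N(C1=CCCC1=O)CC(C)(C)S2` gives 97%.
Compound 2 `CC(=O)Nc1ccc2c(c1)N(C1=CCCC1=O)CC(C)(C)S2` gives 97%.
Compound 3 `CC1CN(C2=CCCC2=O)c2cc(C(F)(F)F)ccc2S1` gives 94%.

In a functional assay on aorta (Rattus norvegicus, strain Wistar) (a lower number here means a smaller maximal response, a higher number a larger maximal response), compound 2 stands level with compound 1, the two together the highest of the three numbers, and compound 3 sits within the scatter of both. Compound 4 `CC1(C)CN(C2=CCCC2=O)c2ccccc2S1` has not yet been measured. The change from compound 2 is hydrogen in place of acetamido on an aromatic carbon. Going by the values given here, only one measured step touches this place: no change at the digits printed from compound 1 to compound 2 (within the scatter), where acetamido replaced ethyl on an aromatic carbon without any shift. Swapping groups at that carbon has so far left the maximal response where it was, so removing the acetamido altogether is expected to give no step beyond the scatter, a number 2 percentage points lower from compound 2 to compound 4 (within the scatter). Compound 4 is therefore estimated at 95%, in a range from 85% to 102%.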

Compound 4, largest response reached (Emax), in percent of the reference or control that the assay uses: 90%
Compound 4: middle estimate off by 5 percentage points, on the high side; low and high end bracket the measured number.
By their numbers in this assay, from the lowest: compounds 4, 3, 1 and 2 (each within the scatter of the next).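

In this assay, the new comparison is with an aromatic carbon that bears only hydrogen: replacing acetamido gives a number 7 percentage points lower from compound 2 to compound 4 (within the scatter), and replacing ethyl gives a number 7 percentage points lower from compound 1 to compound 4 (within the scatter). Neither group is therefore shown to be needed for the maximal response, which the earlier swap of one group for the other could not show. Nothing available here explains this result. Still open, from the compounds shown here alone, is whether an amine, a carboxylic acid or a longer chain on this carbon would produce a step beyond the scatter.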